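Isopropyl on the amidine: cytotoxicity across two core frameworks

The compounds below may be only part of what the source reports. "The series", "measured", "known", "first", "only" and "open" are said of these compounds alone.

Compound 1 `N=C(N)c1ccc2cc(-c3cccc(OCCCOc4ccccc4)c3)oc2c1` and compound 2 `CC(C)NC(=N)c1ccc2cc(-c3cccc(OCCCOc4ccccc4)c3)oc2c1` share one core; compound 3 `N=C(N)c1ccc2oc(-c3ccc(OCCCCCCOc4ccccc4)cc3)cc2c1` and compound 4 `CC(C)NC(=N)c1ccc2oc(-c3ccc(OCCCCCCOc4ccccc4)cc3)cc2c1` share another, and the difference between the two cores is not broken down here. In an ADME assay on L6 cells (Rattus norvegicus) for cytotoxicity, read by resazurin assay, with a stated time of 70 h (on this read-out lower numbers stand for stronger inhibition and higher numbers for weaker inhibition), compound 1 gives 19800 nM, compound 2 gives 82300 nM and compound 3 gives 3300 nM. The change isopropyl in place of hydrogen on an amine nitrogen produced a 4.2-fold higher number from compound 1 to compound 2 (0.62 log units; beyond the scatter). The same change, (isopropyl in place of hydrogen on an amine nitrogen), appears in this assay once more and, made on the same kind of place, is expected to carry compound 4 by a step of about a 4.2-fold higher number from compound 3 to compound 4 (0.63 log units; beyond the scatter), resting on the step seen from compound 1 to compound 2. On that basis compound 4 is estimated at 14000 nM, with a plausible range from 6000 nM to 35000 nM.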

Compound 4, half-maximal inhibitory concentration: 800 nM
The estimate for compound 4 lay 18-fold (1.24 log units) above the measured number; the measured number lies below the stated range.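

In this assay, isopropyl in place of hydrogen on an amine nitrogen gave a 4.1-fold lower number from compound 3 to compound 4 (0.62 log units; beyond the scatter), so on these two cores the same change ran in opposite directions: the same change on two cores in this assay, a 4.2-fold higher number (0.62 log units; beyond the scatter) from compound 1 to compound 2 and a 4.1-fold lower number (0.62 log units; beyond the scatter) from compound 3 to compound 4, 17-fold (1.23 log units) apart, beyond the scatter of two such steps

Within this series, the step on the core of compound 1 therefore gave no reliable guide to the step on the core of compound 3. Among the compounds shown here, it does not show which feature of the cores sets the two steps apart, as each core offers only a single pair and the difference between them is not broken down.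

Going by these compounds, whether the reversal goes with the longer chain or with another part of the core remains open. So does whether a methyl or a cyclopentyl on that amine nitrogen would follow the isopropyl on either core.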